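From 4-chlorophenyl to 2,4,6-trimethylphenyl on a shared core

A few compounds are considered here, and "the series" means these few. Any claim that something is new, unique, unknown or untested is made for them only; others in the source may bear on it.

Compound 1 `Cc1c(NC(=O)CN2C(=O)S/C(=C\c3ccc([N+](=O)[O-])cc3)C2=O)c(=O)n(-c2ccccc2)n1C`: > 100000 nM (a limit of the assay)
Compound 2 `Cc1c(NC(=O)CN2C(=O)S/C(=C\c3ccc(Br)cc3)C2=O)c(=O)n(-c2ccccc2)n1C`: 17100 nM
Compound 3 `Cc1c(NC(=O)CN2C(=O)S/C(=C\c3ccc(Cl)cc3)C2=O)c(=O)n(-c2ccccc2)n1C`: 28900 nM

All three compounds were tested in a functional assay on PC-3 cells (Homo sapiens) for inhibition, read by MTT assay, with a stated time of 48 h (on this read-out higher numbers stand for weaker inhibition and lower numbers for stronger inhibition), and differ only in one group on the aromatic ring. For compound 1, > 100000 nM is a limit and not a number. Within the data shown here, compound 3 stands level with compound 2, as the only comparison between two true numbers is a 1.7-fold higher number from compound 2 to compound 3 (0.23 log units; within the scatter) and so gives no ranking.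

Compound 4 `Cc1cc(C)c(/C=C2\SC(=O)N(CC(=O)Nc3c(C)n(C)n(-c4ccccc4)c3=O)C2=O)c(C)c1` is not yet measured. The change 2,4,6-trimethylphenyl in place of 4-chlorophenyl on a double-bonded chain carbon bound to a double-bonded ring carbon puts 2,4,6-trimethylphenyl in place of 4-chlorophenyl on a double-bonded chain carbon bound to a double-bonded ring carbon.

Among the measured compounds shown here, no measured step makes this swap. The nearest are an at least 5.8-fold lower number from compound 1 to compound 2 (0.76 log units; beyond the scatter) and an at least 3.4-fold lower number from compound 1 to compound 3 (0.53 log units; beyond the scatter), which show that changing this group can matter. In this assay no clear step in either direction is therefore expected, but with wide uncertainty. The expected change is a 1.0-fold higher number from compound 3 to compound 4 (0.02 log units; within the scatter) (an estimate only). For compound 4 the estimated value is 30000 nM (expected range 10000 nM to 90000 nM).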

Compound 4, half-maximal inhibitory concentration: 81600 nM
Estimate against measurement, compound 4: 2.7-fold (0.43 log units) below, within the range that was stated.
By their numbers in this assay, from the lowest: compounds 2 and 3 (each within the scatter of the next); then compound 4. At a limit, above all of these: compound 1.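

In this assay, putting 2,4,6-trimethylphenyl in this place gives a 2.8-fold higher number from compound 3 to compound 4 (0.45 log units; beyond the scatter) and a 4.8-fold higher number from compound 2 to compound 4 (0.68 log units; beyond the scatter), so inhibition is weaker than with either halogen-bearing ring. Among these compounds, the earlier steps showed only that replacing the nitro group on the aromatic ring could matter, whereas this change swaps the whole aromatic group and shows that a ring carrying only carbon substituents can also cost inhibition at this place. Compound 1 has a limit and not a true number, and one value in this set remains out of reach for ranking: the limit of > 100000 nM in this assay, at which 1 of the 4 values shown sits. Measured against that limit, the step is an at least 1.2-fold lower number from compound 1 to compound 4 (0.08 log units; that floor lies within the scatter), which gives only a floor.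

Going by these compounds, what a 4-methylphenyl, 4-methoxyphenyl or 4-aminophenyl group would give in this place remains open. The compounds shown also cannot tell whether the three methyl groups of compound 4 act together or whether one alone accounts for the step.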